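Benzamide ring substituent: methyl to chloro in compound 4

The source may hold more compounds than are shown below. What is called first, only, known or untested is meant among the compounds shown, and "the series" means these compounds.

Compound 3 `COc1ccc(-c2cccc(C(=O)N(C)C)c2)cc1S(=O)(=O)Nc1cccc(NCCNC(=O)c2ccccc2C)c1` gives 800 nM in an assay on CHO-K1 cells for agonist activity at Orexin receptor type 2 (Homo sapiens), read by a luciferase reporter (on this read-out lower numbers stand for an effect already at smaller amounts and higher numbers for an effect only at larger amounts of compound), the highest of the two numbers shown in the series. Compound 2 `COc1cccc(C(=O)NCCNc2cccc(NS(=O)(=O)c3cc(-c4cccc(C(=O)N(C)C)c4)ccc3OC)c2)c1` gives 33 nM in this assay, and the step between them reads a 24-fold higher number from compound 2 to compound 3 (1.38 log units; beyond the scatter). Compound 1 `COc1ccc(-c2cccc(C(=O)N(C)C)c2)cc1S(=O)(=O)Nc1cccc(NCCNC(=O)c2ccccc2)c1` reports only a limit, > 10000 nM in this assay. Measured from that limit, an at least 300-fold lower number from compound 1 to compound 2 (2.48 log units; beyond the scatter) and an at least 12-fold lower number from compound 1 to compound 3 (1.09 log units; beyond the scatter). Compound 4 `COc1ccc(-c2cccc(C(=O)N(C)C)c2)cc1S(=O)(=O)Nc1cccc(NCCNC(=O)c2ccccc2Cl)c1` differs from compound 3 by chloro in place of methyl on an aromatic carbon. Among the measured compounds shown here, no measured step exchanges methyl for chloro; the nearest evidence, an at least 12-fold lower number from compound 1 to compound 3 (1.09 log units; beyond the scatter), only shows that methyl on that aromatic carbon is favoured over hydrogen. A step within the scatter is therefore expected, a 1.1-fold lower number from compound 3 to compound 4 (0.06 log units; within the scatter). Compound 4 is estimated at 700 nM, between 250 nM and 2500 nM.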

Compound 4, half-maximal effective concentration: 31 nM
Compound 4: middle estimate off by 23-fold (1.35 log units), on the high side; the whole stated range lies above it.
By their numbers in this assay, from the lowest: compounds 4 and 2 (each within the scatter of the next); then compound 3. At a limit, above all of these: compound 1.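

At this aromatic carbon, ortho to a large group, the identity of the substituent matters as well as its presence: a 26-fold lower number from compound 3 to compound 4 (1.41 log units; beyond the scatter). With chloro there, the 2-chlorophenyl amide stands level with the 3-methoxyphenyl amide, a 1.1-fold lower number from compound 2 to compound 4 (0.03 log units; within the scatter), so two different aryl groups on the carbonyl carbon reach the same range. The comparison with hydrogen, an at least 320-fold lower number from compound 1 to compound 4 (2.50 log units; beyond the scatter), is measured from a limit: the limit of > 10000 nM in this assay, at which 1 of the 4 values shown sits.

Open, on these data alone, is how bromo or trifluoromethyl on this carbon would compare with chloro. Also open, as far as these compounds go, is whether chloro and methoxy together on one ring would add up.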